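This account rests on a few compounds, and the source may have more. Where it says the series, first, only, none or still open, it means among the compounds named here.

The measured compounds:
compound 1, `Cn1cnnc1SCC(=O)N/N=c1/scc(-c2ccc(C#N)cc2)n1-c1ccccc1`, which in a functional assay on C6 cells (Rattus norvegicus) for cytotoxicity, read by MTT assay, with a stated time of 24 h, tested at 100 ug/mL (a higher number here means a weaker effect of the compound at the concentration tested, a lower number a stronger effect), gives 55.2%
compound 2, `Cc1ccc(-c2cs/c(=N/NC(=O)CSc3nncn3C)n2-c2ccccc2)cc1`, which in this assay gives 39.6%

Among the compounds with values here, compound 1 stands highest of the two numbers; its only neighbour is compound 2, reached by a number 15.6 percentage points lower from compound 1 to compound 2 (beyond the scatter). Compound 3, `N#Cc1ccc(-c2cs/c(=N/NC(=O)CSc3nnnn3-c3ccccc3)n2-c2ccccc2)cc1`, has not yet been measured in this assay. It differs from compound 1 in one place: 1-phenyl-1H-tetrazol-5-yl in place of 4-methyl-4H-1,2,4-triazol-3-yl on a sulfur. Within the data shown here, the single measured step, a number 15.6 percentage points lower from compound 1 to compound 2 (beyond the scatter), alters a group on an aromatic carbon and leaves the sulfur untouched, so it does not bear on the change from compound 1 to compound 3. Among the measured compounds shown here, nothing among the measured compounds shows how an exchange of the ring on that sulfur moves the read-out in this assay. With no comparison to lean on, no step beyond the scatter is expected in either direction, and the expected step is a number 3.2 percentage points lower from compound 1 to compound 3 (within the scatter). Compound 3 is therefore estimated to give about 52% in this assay, within a range from 33% to 72%. For the measured compounds named here, the range is kept wide; no measured step informs this change.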

Compound 3, a percentage reported as activity, at one concentration (the size of the read-out at that concentration, not a potency): 59.8%
Estimate against measurement, compound 3: 7.8 percentage points below, and the stated range covers the measured number.
By their numbers in this assay, from the lowest: compound 2; then compounds 1 and 3 (each within the scatter of the next).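

Within the data shown here, on a sulfur whose other neighbour is a saturated chain carbon, replacing 4-methyl-4H-1,2,4-triazol-3-yl with 1-phenyl-1H-tetrazol-5-yl gives, in this assay, a number 4.6 percentage points higher from compound 1 to compound 3 (within the scatter), and this is the first reading of any change at this position. The entering group is the larger of the two and brings a six-membered aromatic ring of carbon only, yet compound 1 and compound 3 cannot be told apart at the one concentration tested, so in this pair the read-out does not register the exchange of these two groups. Nothing shown gives a reason for this result.

The compounds shown leave open whether the same exchange would also stay within the scatter with methyl rather than the nitrile on the aromatic carbon, since the 1-phenyl-1H-tetrazol-5-yl group appears here only with the nitrile. They also leave open whether an amine or a carboxylic acid on the added phenyl ring, or a plain alkyl chain such as butyl on the sulfur in place of either ring, would move the read-out beyond the scatter.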